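This account rests on a few compounds, and the source may have more. Where it says the series, first, only, none or still open, it means among the compounds named here.

In a functional assay on MDA-MB-435 cells (Homo sapiens) for cytotoxicity, read by MTT assay, with a stated time of 72 h (on this read-out higher numbers stand for weaker inhibition and lower numbers for stronger inhibition), three amides built on one shared core have been measured. Compound 1 `N[C@H]1CC[C@H](Nc2c(C(=O)NCc3ccco3)nc(Br)c3cccnc23)CC1`, with a furan-2-yl ring, reads > 10000 nM, which is a limit of the assay and not a number. Compound 2 `N[C@H]1CC[C@H](Nc2c(C(=O)NCc3ccc(Cl)cc3Cl)nc(Br)c3cccnc23)CC1` gives 5800 nM, and compound 3 `N[C@H]1CC[C@H](Nc2c(C(=O)NCc3ccccn3)nc(Br)c3cccnc23)CC1` gives 4000 nM. Going by the values given here, these are the only two true numbers, and a 1.5-fold lower number from compound 2 to compound 3 (0.16 log units; within the scatter), so they cannot be told apart.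

Compound 4 `N[C@H]1CC[C@H](Nc2c(C(=O)Nc3ccccc3)nc(Br)c3cccnc23)CC1` differs from compound 3 as follows: phenyl in place of (pyridin-2-yl)methyl on an amide-type nitrogen. The measured steps only exchange the ring on a saturated chain carbon, giving an at least 2.5-fold lower number from compound 1 to compound 3 (0.39 log units; beyond the scatter) and an at least 1.7-fold lower number from compound 1 to compound 2 (0.23 log units; that floor lies within the scatter). Both of these are floors set by the limit of compound 1. Among the compounds with values here, compound 4 has no such chain carbon, so these steps bear on it only loosely, and the data hold no direct precedent. Without one, the expected change is small: a 1.3-fold higher number from compound 3 to compound 4 (0.10 log units; within the scatter), with no move beyond the scatter expected. For compound 4 the estimated value is 5000 nM, with an expected range from 1800 nM to 12000 nM.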

Compound 4, half-maximal inhibitory concentration: 1000 nM
Beside the measured number, compound 4's estimate is 5.0-fold (0.70 log units) above it; measured number outside the range, below it.
By their numbers in this assay, from the lowest: compound 4; then compounds 3 and 2 (each within the scatter of the next). At a limit, above all of these: compound 1.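

Earlier compounds varied only the ring on the saturated chain carbon, whereas compound 4 loses that chain carbon and carries its ring directly on the amide-type nitrogen. In this assay, this change sets compound 4 clearly apart from both compounds with true numbers, giving a 4.0-fold lower number from compound 3 to compound 4 (0.60 log units; beyond the scatter) and a 5.8-fold lower number from compound 2 to compound 4 (0.76 log units; beyond the scatter). The third step, an at least 10-fold lower number from compound 1 to compound 4 (1.00 log units; beyond the scatter), is only a floor: the limit of > 10000 nM in this assay, at which 1 of the 4 values shown sits.

Compound 4 differs from compound 3 in both the chain carbon and the ring, with phenyl replacing (pyridin-2-yl)methyl, and the compounds shown do not separate these two parts of the change. A pyridin-2-yl ring set directly on the amide-type nitrogen, or an unsubstituted benzyl group in that place, would tell them apart.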